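Trifluoromethyl step checked across two cores

This account rests on a few compounds, and the source may have more. Where it says the series, first, only, none or still open, it means among the compounds named here.

Measured compounds:
compound 1 `CC(=O)Oc1ccc(/C=C/C(=O)OCCSc2nc(-c3ccc(S(C)(=O)=O)cc3)n(-c3ccccc3)n2)cc1OC(C)=O` gives 1210 nM
compound 2 `CC(=O)Oc1ccc(/C=C/C(=O)OCCSc2nc(-c3ccc(S(C)(=O)=O)cc3)n(-c3ccc(C(F)(F)F)cc3)n2)cc1OC(C)=O` gives 1060 nM
compound 3 `COc1cc(/C=C/C(=O)OCCSc2nc(-c3ccc(S(C)(=O)=O)cc3)n(-c3ccccc3)n2)ccc1O` gives 840 nM

All three numbers come from an assay on cells (strain Sprague-Dawley) for inhibition of Polyunsaturated fatty acid 5-lipoxygenase (Rattus norvegicus), with a stated time of 30 min; on this read-out lower numbers stand for stronger inhibition and higher numbers for weaker inhibition. Compound 1 and compound 2 differ by trifluoromethyl in place of hydrogen on an aromatic carbon, and that change produced a 1.1-fold lower number from compound 1 to compound 2 (0.06 log units; within the scatter). The difference between the core of compound 3 and the core of compound 1 is not broken down here. The three values of compound 1, compound 2 and compound 3 all lie within the usual scatter of one another, so no order among them and no most or least active member is claimed.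

Compound 4 `COc1cc(/C=C/C(=O)OCCSc2nc(-c3ccc(S(C)(=O)=O)cc3)n(-c3ccc(C(F)(F)F)cc3)n2)ccc1O` is not yet measured. Going by the values given here, it differs from compound 3 by trifluoromethyl in place of hydrogen on an aromatic carbon, which is the same change as the one from compound 1 to compound 2, made on the other core. Among the compounds with values here, there is only this single earlier example of the change, and it stayed within the scatter, so no pattern beyond these compounds is asserted. The step in this assay is expected to be about a 1.1-fold lower number from compound 3 to compound 4 (0.04 log units; within the scatter), because the same change on the other core gave a 1.1-fold lower number from compound 1 to compound 2 (0.06 log units; within the scatter). Compound 4 is accordingly estimated at 760 nM in this assay. The expected range for compound 4 runs from 400 nM to 1500 nM, wide enough to cover the ordinary scatter of a single measurement.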

Compound 4, half-maximal inhibitory concentration: 810 nM
For compound 4 the middle estimate is 1.1-fold (0.03 log units) below the measured one, and the stated range covers the measured number.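

In this assay, the change from phenyl to 4-(trifluoromethyl)phenyl on the core of compound 3 gives a 1.0-fold lower number from compound 3 to compound 4 (0.02 log units; within the scatter). Set beside the earlier step on the core of compound 1, the change reads the same on both cores: the same change on two cores in this assay, a 1.1-fold lower number (0.06 log units; within the scatter) from compound 1 to compound 2 and a 1.0-fold lower number (0.02 log units; within the scatter) from compound 3 to compound 4, 1.1-fold (0.04 log units) apart, within the scatter of two such steps

Within these four compounds, then, the change carries from one core to the other as a step that stays inside the scatter each time, but neither step can be told apart from no step at all, so the agreement concerns two small steps and does not show that a readable effect of this change transfers between cores, nor does it say anything about a third core or another assay.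

The compounds shown leave open whether a different group at this place on the phenyl ring, such as a chlorine atom, a nitrile, an amine or a carboxylic acid, would give a step beyond the scatter, and whether such a step would then hold on both cores. Also open, from the compounds shown here alone, is how the series responds to changes elsewhere in the molecule, for instance a longer chain in the linker.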